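The source may hold more compounds than are shown below. What is called first, only, known or untested is meant among the compounds shown, and "the series" means these compounds.

Measured compounds:
compound 1 `CN1CCC(C(=O)N2Cc3c(NC(=O)NCc4ccccc4)n[nH]c3C2(C)C)CC1` — 2680 nM
compound 2 `CC(C)CC(=O)Nc1n[nH]c2c1CN(C(=O)C1CCN(C3CC3)CC1)C2(C)C` — 320 nM

In a functional assay on A2780 cells (Homo sapiens) for antiproliferative activity, read by fluorescence, with a stated time of 72 h (on this read-out higher numbers stand for weaker inhibition and lower numbers for stronger inhibition), compound 1 gives 2680 nM, the higher of the two numbers, while compound 2 gives 320 nM; the two differ in several places, so only their values can be compared. Compound 3 `CN1CCC(C(=O)N2Cc3c(NC(=O)c4ccccc4)n[nH]c3C2(C)C)CC1` differs from compound 1 in one place: phenyl in place of benzylamino on a carbonyl carbon. Among the compounds with values here, no measured pair shows the effect of this change, so the step is expected to be small, without a clear direction and within the scatter, as a 1.1-fold higher number from compound 1 to compound 3 (0.05 log units; within the scatter). Compound 3 is therefore estimated at 3000 nM, with a range from 800 nM to 12000 nM.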

Compound 3, half-maximal inhibitory concentration: 160 nM
Compound 3: middle estimate off by 19-fold (1.27 log units), on the high side; the whole stated range lies above it.
By their numbers in this assay, from the lowest: compounds 3 and 2 (each within the scatter of the next); then compound 1.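

On a carbonyl carbon of the shared core, the group turns out to matter a great deal: in this assay, phenyl in place of benzylamino gives a 17-fold lower number from compound 1 to compound 3 (1.22 log units; beyond the scatter), well beyond the scatter. The earlier pair differed in several places and could not isolate any such effect, whereas this single change from benzylcarbamoyl to benzoyl does. Nothing at hand accounts for the size of this step. The compounds shown leave open whether phenylacetyl on the same carbonyl carbon, or a pyridine ring in place of phenyl, would track compound 3 or compound 1.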